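A few compounds are considered here, and "the series" means these few. Any claim that something is new, unique, unknown or untested is made for them only; others in the source may bear on it.

For the measured compounds named here, compound 1 `CCCC(C)n1c(CC)nc2c(-c3ccc(O)nc3C(F)(F)F)ccnc21` is one of two compounds measured in an assay for binding affinity to Corticotropin releasing factor receptor (Rattus norvegicus) (a higher number here means a weaker inhibitor, a lower number a stronger inhibitor), where compound 1 gives 602 nM. The other, compound 2 `CCCC(C)n1c(CC)nc2c(-c3ccc(OCC(=O)OCC)nc3C(F)(F)F)ccnc21`, gives 1050 nM in this assay. Between them compound 1 has the lower of the two numbers, but the single step from compound 1 to compound 2 is a 1.7-fold higher number from compound 1 to compound 2 (0.24 log units; within the scatter), so the two compounds cannot be told apart on these data.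

Compound 3 `CCCC(C)n1c(CC)nc2c(-c3ccc(O)nc3C)ccnc21` has not yet been measured in this assay. It differs from compound 1 in one place: methyl in place of trifluoromethyl on an aromatic carbon. Going by the values given here, no measured step touches this position; the only step available, from compound 1 to compound 2, was a 1.7-fold higher number from compound 1 to compound 2 (0.24 log units; within the scatter) and concerns the oxygen on the same ring, not the carbon that carries the trifluoromethyl. The measured record therefore gives no direct guide to the size or direction of the change in this assay, and the expectation must stay wide.

Compound 3 is accordingly expected to give 800 nM in this assay, within a range of 250 nM to 3000 nM. This estimate corresponds to an expected step of a 1.3-fold higher number from compound 1 to compound 3 (0.12 log units; within the scatter).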

Compound 3, inhibition constant: > 10000 nM
Compound 3: a limit, no number; the forecaster's own chance of this, stated with the estimate: 5%; middle value at least 12-fold (1.09 log units) away from the limit.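

In this assay, for the compounds shown here, the trifluoromethyl group on this aromatic carbon, next to the ring nitrogen, proves far more sensitive to change than the earlier compounds could show: methyl in its place gives an at least 16-fold higher number from compound 1 to compound 3 (1.22 log units; beyond the scatter). The reading for compound 3 is a limit of the assay and not a number: the limit of > 10000 nM in this assay, at which 1 of the 3 values shown sits. Going by these compounds alone, with the hydroxy group and the rest of the core of compound 1 unchanged, this single exchange of trifluoromethyl for methyl accounts for the whole step, whereas the only earlier step, at the oxygen on the same ring, was a 1.7-fold higher number from compound 1 to compound 2 (0.24 log units; within the scatter).

With methyl as the only replacement shown, the compounds leave open how other groups on this carbon would read in this assay, such as a chlorine atom, an ethyl group, a difluoromethyl group or a nitrile, and so whether the fluorine atoms themselves matter or some other feature of trifluoromethyl does. They also leave open whether methyl in place of trifluoromethyl would give a step of similar size with the (ethoxycarbonyl)methyl group of compound 2 on the oxygen.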